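A few compounds are considered here, and "the series" means these few. Any claim that something is new, unique, unknown or untested is made for them only; others in the source may bear on it.

Of the compounds shown here, three built on a shared core have been measured in a functional assay on LOX IMVI cells (Homo sapiens) for inhibition, read by sulforhodamine B assay, with a stated time of 48 h; a lower number here means a stronger inhibitor of growth, a higher number a weaker inhibitor of growth. Compound 1 `O=C(Nc1cccc(-n2cc(-c3ccncc3)c(-c3ccc(Cl)c(O)c3)n2)c1)Nc1cccc(C(F)(F)F)c1` gives 2530 nM in this assay. Compound 2 `COc1cc(-c2nn(-c3cccc(NC(=O)Nc4cc(C(F)(F)F)cc(C(F)(F)F)c4)c3)cc2-c2ccncc2)ccc1Cl` gives 783 nM, and compound 3 `COc1cc(-c2nn(-c3cccc(NC(=O)Nc4ccc(Cl)c(Cl)c4)c3)cc2-c2ccncc2)ccc1Cl` gives 954 nM. Compound 3 thus shows the second highest number of the three; its gap to compound 2 lies within the scatter, while its gap to compound 1 lies beyond it. Compound 4 `COc1cc(-c2nn(-c3cccc(NC(=O)Nc4cccc(C(F)(F)F)c4)c3)cc2-c2ccncc2)ccc1Cl` is not yet measured and differs from compound 3 by 3-(trifluoromethyl)phenyl in place of 3,4-dichlorophenyl on an amide-type nitrogen. Among the compounds with values here, compound 1 also carries a 3-(trifluoromethyl)phenyl group but differs elsewhere too, so no clean precedent exists. The step from compound 3 to compound 4 is expected to be small, a 1.3-fold higher number from compound 3 to compound 4 (0.10 log units; within the scatter), not beyond the scatter. Compound 4 is therefore estimated at 1200 nM, within 500 nM to 3000 nM.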

Compound 4, concentration for 50% growth inhibition: 789 nM
For compound 4 the middle estimate is 1.5-fold (0.18 log units) above the measured one; the range from low to high includes it.
By their numbers in this assay, from the lowest: compounds 2, 4 and 3 (each within the scatter of the next); then compound 1.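

In this assay, the group on the amide-type nitrogen can differ without a clear effect on these compounds: 3-(trifluoromethyl)phenyl in place of 3,4-dichlorophenyl gives a 1.2-fold lower number from compound 3 to compound 4 (0.08 log units; within the scatter), and hydrogen in place of trifluoromethyl on an aromatic carbon gives a 1.0-fold higher number from compound 2 to compound 4 (0.00 log units; within the scatter). Methyl in place of hydrogen on the oxygen gives a 3.2-fold lower number from compound 1 to compound 4 (0.51 log units; beyond the scatter), so this change, unlike the other two, lies beyond the scatter. No supporting measurement is available to explain these results. On these data alone, whether an amine or a carboxylic acid on that aromatic ring, or a longer chain on the oxygen, would change growth inhibition remains open.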